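This account rests on a few compounds, and the source may have more. Where it says the series, first, only, none or still open, it means among the compounds named here.

In a functional assay on MGC-803 cells (Homo sapiens) for cytotoxicity, read by MTT assay, with a stated time of 72 h (a lower number here means a stronger inhibitor, a higher number a weaker inhibitor), compound 1 (`COc1cc2ncnc(NNC(=S)NC(=O)c3ccccc3Cl)c2cc1OC`) gives 6440 nM. Among the two compounds measured, compound 1 carries the highest number. For the measured compounds named here, the only other measured compound is compound 2 (`O=C(NC(=S)NNc1ncnc2ccccc12)c1ccc(F)cc1`), which in this assay gives 3600 nM; the two values sit within the scatter of one another, so neither can be called the stronger inhibitor on these numbers. Compound 2 differs from compound 1 in more than one place, so no single step can be read between them.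

Compound 3 (`COc1cc2ncnc(NNC(=S)NC(=O)c3ccc(C)cc3)c2cc1OC`) has not yet been measured. It is reached from compound 1 by one change: 4-methylphenyl in place of 2-chlorophenyl on a carbonyl carbon. The rest of the shared core, the thiosemicarbazide chain and the acyl linkage are unchanged.

Going by the values given here, no measured step of this kind is available to lean on; the two values in hand only show that a different halogenated aryl amide, in compound 2, lands in the same neighbourhood. The step from compound 1 to compound 3 is therefore expected to be modest, a 1.3-fold lower number from compound 1 to compound 3 (0.11 log units; within the scatter), without a clear direction beyond the scatter. Compound 3 is expected to give about 5000 nM, within a range from 1800 nM to 14000 nM.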

Compound 3, half-maximal inhibitory concentration: 19700 nM
The estimate for compound 3 lay 3.9-fold (0.60 log units) below the measured number, outside the stated range (above it).
By their numbers in this assay, from the lowest: compounds 2 and 1 (each within the scatter of the next); then compound 3.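

In this assay, for the compounds shown here, the aryl group on the carbonyl carbon turns out to matter: 4-methylphenyl in place of 2-chlorophenyl gives a 3.1-fold higher number from compound 1 to compound 3 (0.49 log units; beyond the scatter) and so a weaker inhibitor, in the only single-change comparison available here. The shared core, the thiosemicarbazide chain and the acyl linkage are unchanged. The only structural difference is the exchange of one aryl group for the other, even though both have the same count of heavy atoms and neither has any hydrogen-bond donors or acceptors. No measurement is available that would explain the difference.

The exchange removes the chlorine and adds the methyl at a different place on the ring in one step, so the compounds shown cannot separate the identity of the substituent from where it sits, a question that 4-chlorophenyl and 2-methylphenyl on the same carbonyl carbon would address. Also open, from the compounds shown here alone, is how unsubstituted phenyl or 4-methoxyphenyl would compare with these two groups on the same core and chain.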